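The source may report more compounds than this note shows. Statements on the series, on what has been measured and on what is new or still open speak of the compounds shown alone.

Measured so far:
Compound 1 `Cc1ccc(S(=O)(=O)NC(=O)Nc2ccccc2C(=O)/C=C/c2ccccc2)cc1` gives 25 ug/mL in an ADME assay on the whole organism for cytotoxicity, with Artemia salina as the target, with a stated time of 24 h; a higher number here means that more compound is needed for the effect, a lower number that less compound is needed.
Compound 2 `Cc1ccc(S(=O)(=O)NC(=O)Nc2ccccc2C(=O)/C=C/c2cc(O)ccc2[N+](=O)[O-])cc1` gives 18.3 ug/mL in this assay.

For the measured compounds named here, compound 2 stands at the lowest of these two numbers, but the gap to compound 1 is small: the one measured step, a 1.4-fold lower number from compound 1 to compound 2 (0.14 log units; within the scatter), does not reach beyond what repeated measurements of this kind usually scatter. In plain terms, the two compounds behave alike in this assay.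

Compound 3 `Cc1ccc(S(=O)(=O)NC(=O)Nc2ccccc2C(=O)/C=C/c2cccc(Br)c2)cc1` differs from compound 2 at a single place: 3-bromophenyl in place of 5-hydroxy-2-nitrophenyl on a double-bonded chain carbon bound to a double-bonded chain carbon. The aryl group at the end of the double-bonded chain is exchanged again, at the same place where compound 1 and compound 2 differ. Going by the values given here, that one step is the only guide available, and it was within the scatter. With compound 1 and compound 2 this close together despite a marked change of the same group, nothing in the data points to a step beyond the scatter for compound 3, in either direction.

Compound 3 is therefore expected to sit near both measured compounds, the estimated step being a 1.2-fold higher number from compound 2 to compound 3 (0.08 log units; within the scatter). The estimated value for compound 3 is 22 ug/mL, with a range from 11 ug/mL to 45 ug/mL.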

Compound 3, concentration for half-maximal effect: 4.02 ug/mL
Estimate against measurement, compound 3: 5.5-fold (0.74 log units) above; the measured number lies below the stated range.
By their numbers in this assay, from the lowest: compound 3; then compounds 2 and 1 (each within the scatter of the next).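

In this assay the aryl group at the end of the double-bonded chain proves able to move the number: 3-bromophenyl in place of 5-hydroxy-2-nitrophenyl gives a 4.6-fold lower number from compound 2 to compound 3 (0.66 log units; beyond the scatter) and so goes beyond the scatter, which the earlier exchange at this place did not. Bromo in place of hydrogen on an aromatic carbon gives a 6.2-fold lower number from compound 1 to compound 3 (0.79 log units; beyond the scatter) and is the plainest comparison, with nothing else altered; adding this one group to the phenyl of compound 1 matters more here than the hydroxy and nitro groups of compound 2 did. Nothing measured here offers an explanation for this drop.

The compounds shown leave open whether the step belongs to bromo in particular or would also appear with another group at the same place, such as chloro, methyl or methoxy. As far as these compounds go, it is also open whether the lower number depends on the rest of the molecule, as all three compounds carry the shared core unchanged.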